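Methyl added on the anilide ring of a benzoate ester analogue

A few compounds are considered here, and "the series" means these few. Any claim that something is new, unique, unknown or untested is made for them only; others in the source may bear on it.

Compound 1 `CC(=O)Oc1ccc(-c2ccc(F)cc2F)cc1C(=O)Nc1ccccc1C` gives 19.6% in a functional assay on the whole organism (Ear) for inhibition, with Mus musculus as the target, at a dose of 40 mg/kg by the oral route; a higher number here means more inhibition at the dose given (going by the name of the read-out), a lower number less inhibition. Compound 2 `CC(=O)Oc1ccc(-c2ccc(F)cc2F)cc1C(=O)Nc1cc(C)ccc1C` carries the change (methyl in place of hydrogen on an aromatic carbon), sitting meta to a large group and para to a methyl group, and it gives 22% in this assay, a step of a number 2.4 percentage points higher from compound 1 to compound 2 (within the scatter). Compound 3 `O=C(Oc1ccc(-c2ccc(F)cc2F)cc1C(=O)Nc1ccccc1)c1ccccc1` gives 19.8% in this assay; how its core differs from that of compound 1 is not broken down here. Compound 4 `Cc1ccccc1NC(=O)c1cc(-c2ccc(F)cc2F)ccc1OC(=O)c1ccccc1` is the not yet measured analogue of compound 3 with the same kind of change, (methyl in place of hydrogen on an aromatic carbon), here ortho to a large group. Because the earlier step of a number 2.4 percentage points higher from compound 1 to compound 2 (within the scatter) stayed within the scatter, the step from compound 3 to compound 4 is expected to be similar, about a number 2.2 percentage points higher from compound 3 to compound 4 (within the scatter). Compound 4 is accordingly estimated at 22%, between 12% and 32%.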

Compound 4, a percentage reported as inhibition, in the whole organism at one dose (the size of the read-out at that dose, not a potency): 21.4%
Beside the measured number, compound 4's estimate is 0.6 percentage points above it, and the stated range covers the measured number.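

In this assay the methyl change gives a step of the same size on both cores, read here as a number 1.6 percentage points higher from compound 3 to compound 4 (within the scatter): the same change on two cores in this assay, a number 2.4 percentage points higher (within the scatter) from compound 1 to compound 2 and a number 1.6 percentage points higher (within the scatter) from compound 3 to compound 4, 0.8 percentage points apart, within the scatter of two such steps. This shows that the result carried from one core to the other in this pair, but since neither step stands out from the scatter, it shows no gain in inhibition from the methyl on either core, and the methyl, here ortho to a large group, does not sit at the same place in the two steps. The exchange of groups on the carbonyl carbon, a number 1.8 percentage points higher from compound 1 to compound 4 (within the scatter), likewise stays within the scatter.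

What the compounds shown leave open is whether a different group on the anilide ring, such as an amine or a carboxylic acid, would move the number beyond the scatter. The same is open for a longer chain on the carbonyl carbon.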